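A few compounds are considered here, and "the series" means these few. Any claim that something is new, unique, unknown or untested is made for them only; others in the source may bear on it.

Compound 1 `Cn1c(=O)c(S(=O)(=O)c2ccc(Cl)cc2Cl)cc2cnc(Nc3ccc4[nH]ccc4c3)nc21`: 1000 nM
Compound 2 `Cn1c(=O)c(C(=O)Nc2ccc(F)cc2F)cc2cnc(Nc3ccc4[nH]ccc4c3)nc21`: 5000 nM
Compound 3 `Cn1c(=O)c(C(=O)Nc2ccc(F)cc2)cc2cnc(Nc3ccc4[nH]ccc4c3)nc21`: 5000 nM

In a functional assay on K562 cells (Homo sapiens) for inhibition, read by trypan blue exclusion, with a stated time of 72 h (on this read-out higher numbers stand for weaker inhibition and lower numbers for stronger inhibition), compound 3 gives 5000 nM, level with compound 2, and these two share the highest number of the set. Compound 4 `Cn1c(=O)c(S(=O)(=O)c2ccc(Cl)cc2)cc2cnc(Nc3ccc4[nH]ccc4c3)nc21` has not yet been measured. It carries (4-chlorophenyl)sulfonyl in place of the (4-fluorophenyl)carbamoyl of compound 3, on an aromatic carbon: (4-chlorophenyl)sulfonyl in place of (4-fluorophenyl)carbamoyl on an aromatic carbon.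

The closest guides are the two steps that swap a sulfonyl group for a carbamoyl group, a 5.0-fold higher number from compound 1 to compound 3 (0.70 log units; beyond the scatter) and a 5.0-fold higher number from compound 1 to compound 2 (0.70 log units; beyond the scatter). Both run opposite to the change made here, so they point to a lower number. Among the measured compounds shown here, removing a ring fluoro made no visible difference, no change at the digits printed from compound 2 to compound 3 (within the scatter), but this is a single case, and no measured pair tests the loss of a chloro from a sulfonyl compound. The expected step is therefore similar in size, a 3.8-fold lower number from compound 3 to compound 4 (0.59 log units; beyond the scatter), towards stronger inhibition in this assay. Compound 4 is estimated at 1300 nM, with an expected range from 500 nM to 3500 nM.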

Compound 4, half-maximal inhibitory concentration: 100 nM
Compound 4: middle estimate off by 13-fold (1.11 log units), on the high side; measured number outside the range, below it.
By their numbers in this assay, from the lowest: compound 4; then compound 1; then compounds 2 and 3 (each within the scatter of the next).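

In this assay, replacing a carbamoyl group with (4-chlorophenyl)sulfonyl at this aromatic carbon can have a large effect, with a 50-fold lower number from compound 3 to compound 4 (1.70 log units; beyond the scatter) and a 50-fold lower number from compound 2 to compound 4 (1.70 log units; beyond the scatter). A ring halogen can also matter here, but the effect depends on the compounds compared: losing a chloro from the sulfonyl group gives a 10-fold lower number from compound 1 to compound 4 (1.00 log units; beyond the scatter), whereas losing a fluoro from the carbamoyl group gives no change at the digits printed from compound 2 to compound 3 (within the scatter). Nothing available explains this difference.

Going by these compounds, the step from compound 3 to compound 4 changes both the link to the ring and the halogen, so the share of each remains open; (4-fluorophenyl)sulfonyl and (4-chlorophenyl)carbamoyl would separate them. Also open, on these data alone, is whether the ring halogen is needed at all, which plain phenylsulfonyl would test, and whether the ring itself is needed, which methylsulfonyl would test.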